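Swapping one hydroxyphenyl isomer on a shared pyridine core

The source may hold more compounds than are shown below. What is called first, only, known or untested is meant among the compounds shown, and "the series" means these compounds.

Compound 3 `Oc1cccc(-c2cc(-c3ccsc3)cc(-c3cccc(O)c3)n2)c1` gives 1310 nM in a functional assay on DU-145 cells (Homo sapiens) for cytotoxicity, read by CCK-8 assay (a lower number here means a stronger inhibitor, a higher number a weaker inhibitor), the lowest of the two numbers reported, with compound 1 `Oc1ccc(-c2cc(-c3cccs3)cc(-c3cccc(O)c3)n2)cc1` at 1890 nM sitting within the scatter of it. Compound 2 `Oc1ccc(-c2cc(-c3ccsc3)cc(-c3ccccc3O)n2)cc1` reaches only a limit of the assay, > 50000 nM, in this assay (the limit of > 50000 nM in this assay, at which 1 of the 3 values shown sits). Compound 4 `Oc1ccc(-c2cc(-c3ccsc3)cc(-c3cccc(O)c3)n2)cc1` has not yet been measured; it differs from compound 3 by 4-hydroxyphenyl in place of 3-hydroxyphenyl on an aromatic carbon next to the ring nitrogen. Compound 1 carries the same pair of hydroxyphenyl groups and lands close to compound 3, so the change is expected to stay within the scatter, a 1.2-fold higher number from compound 3 to compound 4 (0.09 log units; within the scatter). Compound 4 is estimated at 1600 nM, between 600 nM and 4500 nM.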

Compound 4, half-maximal inhibitory concentration: 2230 nM
Estimate against measurement, compound 4: 1.4-fold (0.14 log units) below, within the range that was stated.
By their numbers in this assay, from the lowest: compounds 3, 1 and 4 (each within the scatter of the next). At a limit, above all of these: compound 2.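

Exchanging 3-hydroxyphenyl for 4-hydroxyphenyl on this aromatic carbon next to the ring nitrogen is tolerated, with a 1.7-fold higher number from compound 3 to compound 4 (0.23 log units; within the scatter), and thiophen-3-yl in place of thiophen-2-yl likewise stays within the scatter, with a 1.2-fold higher number from compound 1 to compound 4 (0.07 log units; within the scatter). Against this, 3-hydroxyphenyl in place of 2-hydroxyphenyl gives an at least 22-fold lower number from compound 2 to compound 4 (1.35 log units; beyond the scatter), so compound 2 alone stands apart among these compounds. The value of compound 2 is a limit, not a number: the limit of > 50000 nM in this assay, at which 1 of the 4 values shown sits.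

Whether the hydroxyl is needed at all remains open, as every compound shown carries hydroxyphenyl groups. From the compounds shown here alone, how an aminophenyl or a carboxylic acid would fare at this position also remains unknown.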